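Aryl versus alkyl groups on the ring nitrogen

This account rests on a few compounds, and the source may have more. Where it says the series, first, only, none or still open, it means among the compounds named here.

compound 1 `O=C1NC2(CC2c2ccc3cccc(OCc4ccccc4)c3n2)C(=O)N1c1ccc(C(F)(F)F)cc1`: 300 mg/kg
compound 2 `O=C1NC2(CC2c2ccc3cccc(OCc4ccccc4)c3n2)C(=O)N1c1ccc(Br)cc1`: 300 mg/kg
compound 3 `CCC(CO)N1C(=O)NC2(CC2c2ccc3cccc(OCc4ccccc4)c3n2)C1=O`: 30 mg/kg

In a functional assay on the whole organism (strain Kunming) with Mus musculus as the target, in the maximal electroshock model, with a stated time of 4 h (a lower number here means that less compound is needed, a higher number that more compound is needed for the effect), compound 3 stands lowest of the three numbers; compound 1 and compound 2 share its core but carry an aryl group on the ring nitrogen. Compound 4 `O=C1NC2(CC2c2ccc3cccc(OCc4ccccc4)c3n2)C(=O)N1c1ccc([N+](=O)[O-])cc1` differs from compound 3 by 4-nitrophenyl in place of 1-(hydroxymethyl)propyl on an amide-type nitrogen in a ring. Going by the values given here, the steps that bear on this are a 10-fold lower number from compound 1 to compound 3 (1.00 log units; beyond the scatter) and a 10-fold lower number from compound 2 to compound 3 (1.00 log units; beyond the scatter), both running from an aryl group to the 1-(hydroxymethyl)propyl group; compound 4 reverses that move. Also, no change at the digits printed from compound 1 to compound 2 (within the scatter) shows that exchanging one substituent on the aryl ring for another left the number unchanged. Compound 4 is therefore expected to return to the aryl level, a step of a 10-fold higher number from compound 3 to compound 4 (1.00 log units; beyond the scatter). The estimate for compound 4 is 300 mg/kg, with a range from 100 mg/kg to 600 mg/kg.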

Compound 4, minimum effective dose: 300 mg/kg
Estimate against measurement, compound 4: no gap at the digits printed; measured number inside the range.
By their numbers in this assay, from the lowest: compound 3; then compounds 1, 2 and 4 (each within the scatter of the next).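

In this assay, 4-nitrophenyl in place of 1-(hydroxymethyl)propyl on the ring nitrogen gives a 10-fold higher number from compound 3 to compound 4 (1.00 log units; beyond the scatter), while exchanging the aryl substituent gives no change at the digits printed from compound 2 to compound 4 (within the scatter) and no change at the digits printed from compound 1 to compound 4 (within the scatter). The gap to the 1-(hydroxymethyl)propyl group therefore holds for three aryl groups, and nitro, bromo and trifluoromethyl on the aromatic carbon are not told apart here. Nothing available explains this gap. From the compounds shown here alone, it remains open whether the gap follows from the aryl ring as such or from the hydroxymethyl part of the alkyl group; a plain butyl chain or a benzyl group on the ring nitrogen would separate these.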